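The source may report more compounds than this note shows. Statements on the series, on what has been measured and on what is new or still open speak of the compounds shown alone.

Compound 1 `CCCCn1c(Cc2cc(OC)c(OC)c(OC)c2)nc2c(N)nc(F)nc21` is the most potent of the three measured compounds in a functional assay on MCF7 cells (Homo sapiens) for antiproliferative activity (a lower number here means a stronger inhibitor, a higher number a weaker inhibitor), where compound 1 gives 24000 nM. Compound 2 `CCC(CC)Cn1c(Cc2cc(OC)c(OC)c(OC)c2)nc2c(N)ncnc21` gives 158000 nM, and compound 3 `COCCn1c(Cc2cc(OC)c(OC)c(OC)c2)nc2c(N)ncnc21` gives 64600 nM. Compound 4 `C#CCCCn1c(Cc2cc(OC)c(OC)c(OC)c2)nc2c(N)nc(F)nc21` differs from compound 1 by ethynyl in place of methyl on a saturated chain carbon, three bonds along the chain from an aromatic nitrogen, so a methyl becomes an ethynyl three bonds along the chain from an aromatic nitrogen. For the measured compounds named here, the one measured step, a 2.4-fold lower number from compound 2 to compound 3 (0.39 log units; beyond the scatter), alters the chain on a saturated chain carbon bound to an aromatic nitrogen, a different place, and only loosely bears on this change. Going by the values given here, no measured pair tests a methyl-to-ethynyl swap, so the step in this assay is expected to be small, about a 1.2-fold lower number from compound 1 to compound 4 (0.08 log units; within the scatter). Compound 4 is therefore estimated at 20000 nM, within a range from 7000 nM to 60000 nM.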

Compound 4, half-maximal inhibitory concentration: 11000 nM
Beside the measured number, compound 4's estimate is 1.8-fold (0.26 log units) above it; the range from low to high includes it.
By their numbers in this assay, from the lowest: compound 4; then compound 1; then compound 3; then compound 2.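

Turning butyl into pent-4-yn-1-yl in this assay gives a 2.2-fold lower number from compound 1 to compound 4 (0.34 log units; beyond the scatter), the first measured change on a saturated chain carbon three bonds along the chain from an aromatic nitrogen. So this position accepts an ethynyl group with a modest gain in potency rather than a loss. No available evidence explains this gain.

From the compounds shown here alone, whether the gain comes from the triple bond or simply from the longer chain stays open, and a saturated pentyl chain would separate the two. Going by these compounds, how an amine or a carboxylic acid would fare here is also open.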